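This account rests on a few compounds, and the source may have more. Where it says the series, first, only, none or still open, it means among the compounds named here.

Working notes on the series. Compound 1, `CCCNC(=C\C(=O)/C=C/c1ccc(O)c(OC)c1)/C=C/c1ccc(O)c(OC)c1`, in a functional assay on EA.hy 926 cells (Homo sapiens), read by fluorescence, tested at 10 uM (on this read-out lower numbers stand for a weaker effect and higher numbers for a stronger effect at the one concentration tested), gives 141%. Compound 2, `CCC(C)NC(=C\C(=O)/C=C/c1ccc(O)cc1)/C=C/c1ccc(O)cc1`, in this assay gives 414%. Going by the values given here, of the two numbers so far, compound 1 carries the lower one, and the gap between compound 1 and compound 2 lies beyond the scatter of repeated measurements. The two compounds differ in more than one place, so no single change can be read from that pair.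

Compound 3, `CCCCNC(=C\C(=O)/C=C/c1ccc(O)c(OC)c1)/C=C/c1ccc(O)c(OC)c1`, is not yet measured. Against compound 1 the change is methyl in place of hydrogen on a saturated chain carbon, three bonds along the chain from an amine nitrogen. Among the compounds with values here, no pair measured so far isolates this change, so there is no step in this assay to lean on. Because compound 1 gives 141% and compound 2 gives the higher 414%, a larger alkyl chain on the amine nitrogen is compatible with a stronger read-out, though compound 2 also differs at the aromatic rings.

For compound 3 an increase from compound 1 of a number 34 percentage points higher from compound 1 to compound 3 (beyond the scatter) is expected, modest and possibly within the scatter. Compound 3 is estimated at 175%, with a range from 90% to 330%.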

Compound 3, a percentage reported as activity, at one concentration (the size of the read-out at that concentration, not a potency): 439%
Beside the measured number, compound 3's estimate is 264 percentage points below it; the measured number lies above the stated range.
By their numbers in this assay, from the lowest: compound 1; then compound 2; then compound 3.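

In this assay, going by these compounds alone, methyl in place of hydrogen on a saturated chain carbon, three bonds along the chain from an amine nitrogen, gives the first single change that can be read (a number 298 percentage points higher from compound 1 to compound 3 (beyond the scatter)). Read as propyl to butyl, this shows that the position is not silent: with the rest of compound 1 unchanged, this one change alone moves the read-out by a large step. Nothing available here accounts for the size of that step.

The compounds shown leave open whether a longer chain such as pentyl, or a ring such as cyclohexyl, on the amine nitrogen would extend, hold or reverse this step. They also leave open whether the same change would give a similar step on the core of compound 2.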